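Bromo for Methyl on a Pair of Acrylamide Sulfonamides

The source may hold more compounds than are shown below. What is called first, only, known or untested is meant among the compounds shown, and "the series" means these compounds.

The series is built around an acylsulfonamide linked through an unsaturated amide to a fused dioxygenated bicyclic aromatic unit. Compound 1 `O=C(/C=C/c1ccc2c(c1)OCCO2)NS(=O)(=O)c1ccc(Br)cc1` carries a bromophenyl sulfonyl group and the smaller fused ring. In a functional assay on MCF7 cells (Homo sapiens) for antiproliferative activity, read by MTT assay, with a stated time of 48 h (a lower number here means a stronger inhibitor, a higher number a weaker inhibitor), compound 1 reaches only the limit of the assay, > 100 ug/mL. Compound 2 `Cc1ccc(S(=O)(=O)NC(=O)/C=C/c2ccc3c(c2)OCCCO3)cc1` pairs the larger fused ring with a methylphenyl sulfonyl group. In this assay compound 2 likewise gives only a limit, > 100 ug/mL. Compound 2 therefore stands at the same edge as compound 1: neither shows measurable antiproliferative activity, and the whole shown data set sits at one boundary, (the limit of > 100 ug/mL in this assay, at which 2 of the 2 values shown sit).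

Compound 3 `O=C(/C=C/c1ccc2c(c1)OCCCO2)NS(=O)(=O)c1ccc(Br)cc1` has not yet been tested. It differs from compound 2 by bromo in place of methyl on an aromatic carbon; stated one bond further out, 4-methylphenyl becomes 4-bromophenyl. Compound 3 also shares the bromophenyl sulfonyl group of compound 1, which itself lies at the limit.

Because both neighbours sit at the limit of > 100 ug/mL in this assay, at which 2 of the 2 values shown sit, no change beyond the scatter is expected from compound 2 to compound 3 in this assay, and the expected step is a step that the limit leaves unreadable from compound 2 to compound 3. Compound 3 is estimated to give 120 ug/mL, within 50 ug/mL to 300 ug/mL, most likely reported again as a limit.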

Compound 3, half-maximal inhibitory concentration: > 100 ug/mL
Compound 3: a limit, no number; the forecaster's own chance of this, stated with the estimate: 80%; the middle value lies beyond the limit too.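

Going by these compounds alone, compound 3 gives only a limit, like compound 2, so no step from compound 2 to compound 3 can be read, because the values offer no number to compare: the limit of > 100 ug/mL in this assay, at which 3 of the 3 values shown sit.

The compounds shown leave open whether bromo in place of methyl changes anything in this assay and whether any compound in this series has measurable antiproliferative activity there.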